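Pyridin-2-yl for Dimethylamino in a Porcupine Amide Series

The source may report more compounds than this note shows. Statements on the series, on what has been measured and on what is new or still open speak of the compounds shown alone.

Compound 1 `O=C(CNC(=O)c1nn(-c2ccccc2)c(=O)c2ccccc12)Nc1nccs1` gives > 25000 nM in an assay on L cells for inhibition of Protein-serine O-palmitoleoyltransferase porcupine (Mus musculus), read by reporter gene assay, with a stated time of 24 h (a higher number here means that more compound is needed for the effect, a lower number that less compound is needed), a limit of the assay. Compound 2 `COc1ccc(-n2c(SCC(=O)Nc3nc4ccc(Cl)cc4s3)nc3c(c2=O)SCC3)cc1` gives 35 nM in this assay. Compound 3 `CN(C)c1ccc(NC(=O)CSc2nc3c(c(=O)n2-c2ccccc2)SCC3)cc1` gives > 1000 nM in this assay, again a limit of the assay.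

Two of the three values are limits. Compound 1 sits at the limit of > 25000 nM in this assay, at which 1 of the 3 values shown sits. Compound 3 sits at the limit of > 1000 nM in this assay, at which 1 of the 3 values shown sits, so it has no number of its own, and compound 2 alone provides one. Compound 4 `O=C(CSc1nc2c(c(=O)n1-c1ccccc1)SCC2)Nc1ccc(-c2ccccn2)cc1` differs from compound 3 in one place: pyridin-2-yl in place of dimethylamino on an aromatic carbon. Within the data shown here, no step between measured compounds is available, so the change is judged from compound 2, whose value of 35 nM shows that a low number is reachable. The step from compound 3 to compound 4 is expected to be large and toward a lower number, an at least 20-fold lower number from compound 3 to compound 4 (1.30 log units; beyond the scatter). Compound 4 is estimated at 50 nM, within 8 nM to 500 nM.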

Compound 4, half-maximal effective concentration: 4 nM
Beside the measured number, compound 4's estimate is 13-fold (1.10 log units) above it; measured number outside the range, below it.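

Among these compounds, replacing dimethylamino with pyridin-2-yl gives an at least 250-fold lower number from compound 3 to compound 4 (2.39 log units; beyond the scatter) in this assay, the first step that can be read here, and it shows that the group on this aromatic carbon, para to a large group, strongly affects the read-out. The two groups have equal hydrogen-bond donor and acceptor counts, but the entering group adds an aromatic ring. The true size of the step stays unknown, since compound 3 has only a limit of the assay: the limit of > 1000 nM in this assay, at which 1 of the 4 values shown sits.

The compounds shown leave open whether the ring or its nitrogen matters more. A phenyl or pyridin-3-yl group at the same place would separate the two.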